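The compounds below may be only part of what the source reports. "The series", "measured", "known", "first", "only" and "open" are said of these compounds alone.

Working notes on the series. In a functional assay on the whole organism (strain Sprague-Dawley) for inhibition, with Rattus norvegicus as the target, with a stated time of 10 min (a lower number here means that less compound is needed, a higher number that more compound is needed for the effect), compound 1 `CCOc1ccc(OC)cc1-c1ncc(C(=O)O)c(=O)[nH]1` gives 0.2 mg/kg, and compound 2 `CCOc1ccc(N(C)C)cc1-c1ncc(C(=O)O)c(=O)[nH]1` gives 0.3 mg/kg. Within the data shown here, on these two numbers, compound 2 stands level with compound 1, as the only measured step, a 1.5-fold higher number from compound 1 to compound 2 (0.18 log units; within the scatter), lies within the scatter.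

The next compound is compound 3 `CCOc1ccc(S(N)(=O)=O)cc1-c1ncc(C(=O)O)c(=O)[nH]1`, which has sulfamoyl in place of dimethylamino on an aromatic carbon. The step from compound 1 to compound 2 is the only one that bears on this change, since it was made at the same aromatic carbon. Among the measured compounds shown here, no measured compound carries sulfamoyl, so this single step gives weak guidance. A small move towards a higher number in this assay is expected, with little confidence in its direction. The expected change is a 1.7-fold higher number from compound 2 to compound 3 (0.22 log units; within the scatter). For compound 3 the estimate is 0.5 mg/kg, with an expected range of 0.15 mg/kg to 2 mg/kg.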

Compound 3, dose for 50% inhibition: > 50 mg/kg
Compound 3: a limit, no number; the forecaster's own chance of this, stated with the estimate: 10%; middle value at least 100-fold (2.00 log units) away from the limit.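

Among these compounds, at this position, para to an ethoxy group, the only earlier change, dimethylamino for methoxy, stayed within the scatter, so the two earlier compounds gave no sign that the group here matters in this assay. Sulfamoyl shows that it does, with an at least 160-fold higher number from compound 2 to compound 3 (2.22 log units; beyond the scatter) and an at least 250-fold higher number from compound 1 to compound 3 (2.39 log units; beyond the scatter). The result for compound 3 is a limit of the assay, not a number: the limit of > 50 mg/kg in this assay, at which 1 of the 3 values shown sits.

The compounds shown do not separate the parts of sulfamoyl, so it remains open whether the change follows from its amide hydrogens, which dimethylamino lacks, or from the sulfonyl unit itself. A methylsulfonyl group, a dimethylsulfamoyl group or a carboxamide at the same carbon would tell these apart, and would show whether any such group stays level with compound 1 and compound 2.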